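Cyclopentyl to butyl on the ether oxygen

The source may hold more compounds than are shown below. What is called first, only, known or untested is meant among the compounds shown, and "the series" means these compounds.

Compound 3 `Nc1ccc2cccc(OCC3CCCC3)c2n1` gives 53 nM in an assay on cells with melanin-concentrating hormone receptor 1 (Homo sapiens) as the target, read by radioligand binding (on this read-out lower numbers stand for stronger inhibition and higher numbers for weaker inhibition), the lowest of the two numbers in hand. Compound 1 `Nc1ccc2cccc(OC3CCCCC3)c2n1` gives 361 nM in this assay, and the step of a 6.8-fold lower number from compound 1 to compound 3 (0.83 log units; beyond the scatter) lies beyond the scatter. Compound 2 `CCOCCOc1cccc2ccc(N)nc12` reaches only a limit in this assay, > 2000 nM. The steps of an at least 5.5-fold higher number from compound 1 to compound 2 (0.74 log units; beyond the scatter) and an at least 37-fold lower number from compound 2 to compound 3 (1.57 log units; beyond the scatter) show the ethoxymethyl chain at this place weaker than either ring, while cyclopentylmethyl stands stronger than cyclohexyl. Compound 4 `CCCCCOc1cccc2ccc(N)nc12` differs from compound 3 by butyl in place of cyclopentyl on a saturated chain carbon bound to an oxygen on an aromatic ring. The nearest measured precedent is compound 2, whose chain at this place gave only a limit in this assay, but that chain carried an ether oxygen and butyl carries none, and the match is partial. A modest step toward a higher number is expected for compound 4, a 5.7-fold higher number from compound 3 to compound 4 (0.75 log units; beyond the scatter), with wide uncertainty in both directions. For compound 4 the estimate in this assay is 300 nM, between 80 nM and 1500 nM.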

Compound 4, half-maximal inhibitory concentration: 580 nM
Beside the measured number, compound 4's estimate is 1.9-fold (0.29 log units) below it, and the stated range covers the measured number.
By their numbers in this assay, from the lowest: compound 3; then compounds 1 and 4 (each within the scatter of the next). At a limit, above all of these: compound 2.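

In this assay the open chain falls well short of the ring it replaces (an 11-fold higher number from compound 3 to compound 4 (1.04 log units; beyond the scatter)), so at this position the five-membered ring of cyclopentylmethyl counts and a carbon-only chain does not make up for its loss. A ring alone does not secure a low number, since pentyl and cyclohexyl on the oxygen do not separate (a 1.6-fold higher number from compound 1 to compound 4 (0.21 log units; within the scatter)). The ether oxygen in the chain of compound 2 weighs on top of this, with propyl in place of ethoxy giving an at least 3.4-fold lower number from compound 2 to compound 4 (0.53 log units; beyond the scatter) and the step starting from a limit: the limit of > 2000 nM in this assay, at which 1 of the 4 values shown sits.

Open, from the compounds shown here alone, is whether cyclobutylmethyl or cyclohexylmethyl on the same oxygen would match cyclopentylmethyl. Also open, going by these compounds, is how a chain ending in an amine or a carboxylic acid would read at this place.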